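Cytotoxicity limits and a furan side chain

The source may report more compounds than this note shows. Statements on the series, on what has been measured and on what is new or still open speak of the compounds shown alone.

Compound 3 (`COc1cccc(F)c1CNC(=O)c1[nH]c2ccc(Cl)cc2c1S(=O)(=O)c1cc(C)cc(C)c1`) gives > 49900 nM in an ADME assay on MT4 cells (Homo sapiens) for cytotoxicity, read by MTT assay (on this read-out higher numbers stand for lower toxicity in this test and lower numbers for higher toxicity in this test), as a limit of the assay and not a number. Compound 1 (`Cc1cc(C)cc(S(=O)(=O)c2c(C(=O)NCc3cccc(F)c3F)[nH]c3ccc(Cl)cc23)c1`) gives > 51100 nM in this assay as a limit too. Compound 2 (`Cc1cc(C)cc(S(=O)(=O)c2c(C(=O)NCc3cccc(N)c3)[nH]c3ccc(Cl)cc23)c1`) gives > 53400 nM in this assay as a limit as well. Compound 3 therefore has no measured number, and neither of the other two offers one for comparison.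

Compound 4 (`Cc1cc(C)cc(S(=O)(=O)c2c(C(=O)NCC(=O)NCc3ccco3)[nH]c3ccc(Cl)cc23)c1`) has not yet been measured. In it, ((furan-2-yl)methyl)carbamoyl stands in place of 2-fluoro-6-methoxyphenyl on a saturated chain carbon bound to an amide-type nitrogen (((furan-2-yl)methyl)carbamoyl in place of 2-fluoro-6-methoxyphenyl on a saturated chain carbon bound to an amide-type nitrogen). One six-membered aromatic ring of carbon only thus gives way to one five-membered aromatic ring with 1 hetero atom.

The measured steps that bear on this change sit at the same place. They are a step that the two limits leave unreadable from compound 1 to compound 3 together with a step that the two limits leave unreadable from compound 2 to compound 3 and a step that the two limits leave unreadable from compound 1 to compound 2 and so none of them has a size to carry over. None of compounds 1, 2 and 3 carries the entering group. No step beyond the scatter is therefore expected in this assay and no direction can be named. The expected outcome is a step that the limit leaves unreadable from compound 3 to compound 4 and a further limit is the likeliest report. Compound 4 is estimated at 50000 nM with an expected range from 20000 nM to 55000 nM in this estimate.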

Compound 4, half-maximal cytotoxic concentration: > 50000 nM
Compound 4: no number, only a limit; the forecaster's own chance of this, stated with the estimate: 80%; the middle value lies on the limit itself.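

In this assay compound 4 gives > 50000 nM, which is a limit of the assay and not a number. Compound 1, compound 2 and compound 3 carry limits too, so none of the steps among these four compounds can be read. The compounds shown leave open whether their side chains differ at all in this assay.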